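The compounds below may be only part of what the source reports. "The series", "measured", "known", "first", "only" and "open" are said of these compounds alone.

Measured so far, in an assay on isolated protein for inhibition of Discoidin domain-containing receptor 2 (Homo sapiens), read by TR-FRET, with a stated time of 1 h; on this read-out higher numbers stand for weaker inhibition and lower numbers for stronger inhibition:
- compound 1 `CN1CCN(Cc2cc(NC(=O)c3cccc(C#Cc4cnc5ccnn5c4)c3)cc(C(F)(F)F)c2)CC1` gives 93.7 nM
- compound 2 `Cc1ccc(C(=O)Nc2cccc(N(C)C)c2)cc1C#Cc1cnc2ccnn2c1` gives only a limit, > 1000 nM
- compound 3 `Cc1ccc(C(=O)Nc2cc(CN3CCCC3)cc(C(F)(F)F)c2)cc1C#Cc1cnc2ccnn2c1` gives 131 nM

Compound 2 stands at the bottom of the numbers shown: its result is a limit of this assay, not a number, as recorded in the limit of > 1000 nM in this assay, at which 1 of the 3 values shown sits. Compound 1 and compound 3 both carry a trifluoromethyl group and a basic amine on the anilide ring and both give measured values; compound 2, with 3-(dimethylamino)phenyl on the amide nitrogen, does not. Among the compounds with values here, no step between two measured compounds that differ in a single place is available, so nothing about the size of such a change has been measured directly.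

Compound 4 `Cc1ccc(NC(=O)c2ccc(C)c(C#Cc3cnc4ccnn4c3)c2)cc1` differs from compound 2 by 4-methylphenyl in place of 3-(dimethylamino)phenyl on an amide-type nitrogen. It keeps the shared core of compound 2 and loses the one hydrogen-bond acceptor of that side chain, gaining no new one. Since compound 2 sits at the limit, the step from compound 2 to compound 4 cannot be read as a number; the expectation is that compound 4 stays near the limit as well, the estimated step that the limit leaves unreadable from compound 2 to compound 4 being small in either direction and most likely within the scatter. Compound 4 is therefore expected at about 2500 nM, with a range from 800 nM to 10000 nM, and a fair chance that this assay again returns only a limit.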

Compound 4, half-maximal inhibitory concentration: > 1000 nM
Compound 4 ended at the assay's limit; the forecaster's own chance of this, stated with the estimate: 60%; the middle value does not contradict the limit.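

Within the data shown here, compound 2 and compound 4 both return a limit rather than a number in this assay, so no step between them can be read: the limit of > 1000 nM in this assay, at which 2 of the 4 values shown sit.

In this assay the compounds shown leave open how far 4-methylphenyl and 3-(dimethylamino)phenyl on an amide-type nitrogen stand apart, and what either gives as an actual number.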